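The source may hold more compounds than are shown below. What is called first, only, known or untested is meant among the compounds shown, and "the series" means these compounds.

Measured compounds, read-out in a functional assay (muscle tissue) with Cavia porcellus as the target; a lower number here means that less compound is needed, a higher number that more compound is needed for the effect:
compound 1 `COC(=O)C1=C(C)N=C(C)/C(=C(\O)OC)C1c1ccccc1Cl` gives 2.19 nM
compound 2 `COC(=O)C1=C(C)N=C(C)/C(=C(\O)OC)C1c1ccccc1OC` gives 57.5 nM
compound 3 `COC(=O)C1=C(C)N=C(C)/C(=C(\O)OC)C1c1cccc(Br)c1` gives 1.29 nM

Compound 3 has the lowest number of the three in this assay. Its nearest neighbour is compound 1, a 1.7-fold lower number from compound 1 to compound 3 (0.23 log units; within the scatter), a step within the scatter, so the two cannot be ordered. Its furthest is compound 2, a 45-fold lower number from compound 2 to compound 3 (1.65 log units; beyond the scatter), a large step; a 26-fold higher number from compound 1 to compound 2 (1.42 log units; beyond the scatter) is likewise large.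

Compound 4 `COC(=O)C1=C(C)N=C(C)/C(=C(\O)OC)C1c1cc(C)ccc1C` is not yet measured. The change from compound 3 is 2,5-dimethylphenyl in place of 3-bromophenyl on a saturated ring carbon. Both large steps in the series concern the same saturated ring carbon, and both link a methoxy-bearing phenyl to a low-potency number, while the two halogen-bearing phenyls of compound 1 and compound 3 sit close together. For the measured compounds named here, no measured step replaces a halogen with methyl, so the bearing of these steps on compound 4 is indirect. A moderate rise in the number, a 3.9-fold higher number from compound 3 to compound 4 (0.59 log units; beyond the scatter), is expected, with wide uncertainty in either direction. Compound 4 is estimated at 5 nM, range 1 nM to 30 nM.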

Compound 4, half-maximal effective concentration: 100 nM
Compound 4: the middle estimate sits 20-fold (1.30 log units) below what was measured; measured number above the stated range.
By their numbers in this assay, from the lowest: compounds 3 and 1 (each within the scatter of the next); then compounds 2 and 4 (each within the scatter of the next).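

In this assay, a high number at this saturated ring carbon is no longer tied to methoxy: the 2,5-dimethylphenyl group, which holds only carbon, brings a large rise against both halogen-bearing phenyl groups (a 78-fold higher number from compound 3 to compound 4 (1.89 log units; beyond the scatter); a 46-fold higher number from compound 1 to compound 4 (1.66 log units; beyond the scatter)). It cannot be ordered against the 2-methoxyphenyl group (a 1.7-fold higher number from compound 2 to compound 4 (0.24 log units; within the scatter)). Across the four compounds, the two halogen-bearing phenyl groups give low numbers and the two without halogen give high numbers, with no compound going against this, and no measurement shown explains the split.

The compounds shown do not separate the contributions of the two methyl groups, so a single methyl group on the phenyl stays open. Also open, on these data alone, is how a phenyl bearing a nitro group or a trifluoromethyl group would read at this carbon.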